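The source may report more compounds than this note shows. Statements on the series, on what has been measured and on what is new or still open speak of the compounds shown alone.

Three compounds share one core, an arylidene oxindole carrying a methoxy group and a basic side chain, and differ in the substituent on the fused ring and in the amine at the end of the chain. Compound 1 `COc1cc(/C=C2\C(=O)Nc3ccc(Cl)cc32)ccc1OCCCN1CC(C)OC(C)C1` carries a chloro group, and in a functional assay on DU-145 cells (Homo sapiens) for cytotoxicity, read by MTT assay, with a stated time of 48 h (on this read-out lower numbers stand for stronger inhibition and higher numbers for weaker inhibition), compound 1 gives 2710 nM. Compound 2 `COc1cc(/C=C2\C(=O)Nc3ccc(C)cc32)ccc1OCCCN1CC(C)OC(C)C1` carries a methyl group in the same spot; in this assay compound 2 reaches only a limit of the assay, > 20000 nM. The change from chloro to methyl thus brings an at least 7.3-fold higher number from compound 1 to compound 2 (0.86 log units; beyond the scatter). Compound 3 `COc1cc(/C=C2\C(=O)Nc3ccccc32)ccc1OCCCN1CCN(c2ccccn2)CC1` has no substituent on that ring and carries a pyridinylpiperazine chain; in this assay compound 3 also gives only a limit, > 20000 nM, so it stands among the weak compounds, as the limit of > 20000 nM in this assay, at which 2 of the 3 values shown sit, makes clear. Compound 4 `COc1cc(/C=C2\C(=O)Nc3ccc(Cl)cc32)ccc1OCCCN1CCN(c2ccccn2)CC1` differs from compound 3 by chloro in place of hydrogen on an aromatic carbon. Among the compounds with values here, only the step from compound 1 to compound 2 bears on this, and it concerns chloro against methyl rather than chloro against hydrogen, so it points to a gain of uncertain size. The expected step is an at least 2.5-fold lower number from compound 3 to compound 4 (0.39 log units; beyond the scatter), and compound 4 is estimated at 8000 nM, within a range from 2000 nM to 30000 nM.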

Compound 4, half-maximal inhibitory concentration: > 20000 nM
Compound 4: no number, only a limit; the forecaster's own chance of this, stated with the estimate: 35%; middle value at least 2.5-fold (0.39 log units) away from the limit.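

Chloro on this aromatic carbon does not by itself lift a compound out of the weak group: with the 4-(pyridin-2-yl)piperazin-1-yl chain, compound 4 still gives only a limit of the assay in this assay, > 20000 nM. Compound 3 and compound 4 both sit at limits, so the step between them cannot be read, and any gain from chloro on this chain stays hidden, with much of the series now at one ceiling: the limit of > 20000 nM in this assay, at which 3 of the 4 values shown sit. With chloro held fixed, 4-(pyridin-2-yl)piperazin-1-yl in place of 2,6-dimethylmorpholin-4-yl brings an at least 7.3-fold higher number from compound 1 to compound 4 (0.86 log units; beyond the scatter), so the readable value of compound 1 depends on the amine at the end of the chain as well as on the chloro group.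

The compounds shown leave open how chloro compares with hydrogen on the 2,6-dimethylmorpholin-4-yl chain, the only chain here that gives a readable number. Also open, as far as these compounds go, is how a fluoro or bromo group on the same aromatic carbon, or a piperidine at the end of the chain, would read in this assay.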